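A few compounds are considered here, and "the series" means these few. Any claim that something is new, unique, unknown or untested is made for them only; others in the source may bear on it.

Of the compounds shown here, two have numbers so far in a functional assay, read by spectrophotometry (on this read-out higher numbers stand for an effect only at larger amounts of compound and lower numbers for an effect already at smaller amounts), both on the shared core. Compound 1 (`COc1ccc(-c2cc(=O)c3ccc(OCCCN4CCC(C)CC4)cc3o2)cc1`) gives 26.6 nM and compound 2 (`COc1ccc(-c2cc(=O)c3ccc(OCCCCN4CCC(CCO)CC4)cc3o2)cc1`) gives 23.2 nM in these notes. Compound 2 therefore stands level with compound 1, the two lying within the scatter of each other.

Next is compound 3 (`COc1ccc(-c2cc(=O)c3ccc(OCCCCCN4CCC(C)CC4)cc3o2)cc1`), reached from compound 2 by one structural change ((4-methylpiperidin-1-yl)methyl in place of 4-(2-hydroxyethyl)piperidin-1-yl on a saturated chain carbon, four bonds along the chain from an oxygen on an aromatic ring). In words, this is (4-methylpiperidin-1-yl)methyl in place of 4-(2-hydroxyethyl)piperidin-1-yl on a saturated chain carbon, four bonds along the chain from an oxygen on an aromatic ring. Cut one bond further out, it reads (4-(2-hydroxyethyl)piperidin-1-yl)methyl to 2-(4-methylpiperidin-1-yl)ethyl.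

Going by the values given here, only one measured step bears on this (a 1.1-fold lower number from compound 1 to compound 2 (0.06 log units; within the scatter)), and it lies within the scatter. It runs the other way, from the 4-methylpiperidin-1-yl group to the 4-(2-hydroxyethyl)piperidin-1-yl group. Among the compounds with values here, no measured pair tests the chain alone, so the evidence is thin. No step beyond the scatter is expected in this assay for this change. The expected step is small (a 1.1-fold higher number from compound 2 to compound 3 (0.03 log units; within the scatter)). For compound 3 the estimated value is 25 nM, with an expected range from 10 nM to 65 nM.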

Compound 3, half-maximal effective concentration: 31.7 nM
Estimate against measurement, compound 3: 1.3-fold (0.10 log units) below; the measured number falls inside the stated range.
By their numbers in this assay, from the lowest: compounds 2, 1 and 3 (each within the scatter of the next).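

Replacing 4-methylpiperidin-1-yl with 2-(4-methylpiperidin-1-yl)ethyl gives, in this assay, a 1.2-fold higher number from compound 1 to compound 3 (0.08 log units; within the scatter). This pair tests the chain alone with the 4-methylpiperidin-1-yl group kept, and across it the numbers stay level. The exchange of 4-(2-hydroxyethyl)piperidin-1-yl for (4-methylpiperidin-1-yl)methyl, in which the hydroxyl group leaves, gives a 1.4-fold higher number from compound 2 to compound 3 (0.14 log units; within the scatter), so this change also stays within the scatter, and no information is at hand that would account for this flat behaviour.

The compounds shown contain no pair that shares a chain and differs only between 4-methylpiperidin-1-yl and 4-(2-hydroxyethyl)piperidin-1-yl, so the hydroxyethyl group has no reading of its own here. Going by these compounds, it also remains open whether the numbers stay level with a longer chain than that of compound 3, or with a carboxylic acid in place of the hydroxyl group on the piperidine.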